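Triazole in place of methoxymethoxy on the shared core

The source may report more compounds than this note shows. Statements on the series, on what has been measured and on what is new or still open speak of the compounds shown alone.

- compound 1 `CC(C)=CCC[C@]1(C)/C=C/[C@@H](OC(=O)C=C(C)C)[C@](C)(O)/C=C/C(=O)/C(C(=O)O)=C\C1` gives 16100 nM
- compound 2 `CCN(CC)C/C1=C/C[C@](C)(CCC=C(C)C)/C=C/[C@@H](OC(=O)C=C(C)C)[C@](C)(O)/C=C/C1=O` gives 130 nM
- compound 3 `COCOC/C1=C/C[C@](C)(CCC=C(C)C)/C=C/[C@@H](OC(=O)C=C(C)C)[C@](C)(O)/C=C/C1=O` gives 3120 nM

In a functional assay on MCF7 cells (Homo sapiens) for antiproliferative activity, read by MTT assay, with a stated time of 48 h (on this read-out lower numbers stand for stronger inhibition and higher numbers for weaker inhibition), compound 3 stands second highest of the three at 3120 nM and so lies in the middle, with a 5.2-fold lower number from compound 1 to compound 3 (0.71 log units; beyond the scatter) on one side and a 24-fold higher number from compound 2 to compound 3 (1.38 log units; beyond the scatter) on the other.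

Compound 4 `CC(C)=CCC[C@]1(C)/C=C/[C@@H](OC(=O)C=C(C)C)[C@](C)(O)/C=C/C(=O)/C(Cn2cc(CO)nn2)=C\C1` keeps the shared core and carries 4-(hydroxymethyl)-1H-1,2,3-triazol-1-yl in place of methoxymethoxy on a saturated chain carbon bound to a double-bonded ring carbon.

Among the measured compounds shown here, no measured compound carries a triazole, so the measured steps bear on this change only indirectly. They do show that this place matters: a 5.2-fold lower number from compound 1 to compound 3 (0.71 log units; beyond the scatter) is modest, while a 120-fold lower number from compound 1 to compound 2 (2.09 log units; beyond the scatter) and a 24-fold higher number from compound 2 to compound 3 (1.38 log units; beyond the scatter) are large. For the measured compounds named here, neither the leaving nor the entering group has a net charge, and no measured step fixes a direction. In this assay a small step to a slightly lower number is therefore expected, probably within the scatter, though the spread of the measured steps keeps a larger move open either way.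

The estimated step is a 1.7-fold lower number from compound 3 to compound 4 (0.24 log units; within the scatter) (an expectation only).

For compound 4 the estimated value is 1800 nM, with an expected range from 400 nM to 8000 nM.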

Compound 4, half-maximal inhibitory concentration: 2930 nM
Compound 4: the middle estimate sits 1.6-fold (0.21 log units) below what was measured; the range from low to high includes it.
By their numbers in this assay, from the lowest: compound 2; then compounds 4 and 3 (each within the scatter of the next); then compound 1.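

Working notes on this place: in this assay, a 1.1-fold lower number from compound 3 to compound 4 (0.03 log units; within the scatter) shows that exchanging methoxymethoxy for 4-(hydroxymethyl)-1H-1,2,3-triazol-1-yl, which brings a five-membered aromatic ring and a hydrogen-bond donor, gives no difference that can be read beyond the scatter. The diethylamino compound stays well apart from the triazole, with a 23-fold higher number from compound 2 to compound 4 (1.35 log units; beyond the scatter), while the carboxy compound also stays apart, with a 5.5-fold lower number from compound 1 to compound 4 (0.74 log units; beyond the scatter); among the four compounds, the two groups without net charge, methoxymethoxy and the triazole, therefore give values within the scatter of each other despite their different size and ring content. Nothing measured here accounts for this closeness or for the separate position of compound 2.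

Going by these compounds, it remains open whether the low number of compound 2 belongs to diethylamino alone or extends to other amines on this saturated chain carbon, such as dimethylamino, pyrrolidine or morpholine. On these data alone, it is equally open whether the hydroxymethyl on the triazole has any part in the value of compound 4, which a triazole bearing an aminomethyl group or a longer alkyl chain could test.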